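The source may hold more compounds than are shown below. What is called first, only, known or untested is meant among the compounds shown, and "the series" means these compounds.

Compound 1 `C[Se]/C(=N\C(=O)c1cccs1)NC(=O)c1cccs1` gives the lower of the two numbers recorded in a functional assay on HepG2 cells (Homo sapiens) for cytotoxicity, read by MTT assay, with a stated time of 72 h (on this read-out lower numbers stand for higher toxicity in this test and higher numbers for lower toxicity in this test), at 12500 nM. Among the measured compounds shown here, its only neighbour in this set, compound 2 `O=C(/N=C(/NC(=O)c1cc(-c2ccccc2)nc2ccccc12)[Se]Cc1ccccc1)c1cc(-c2ccccc2)nc2ccccc12`, gives 78900 nM in this assay, a gap beyond the usual scatter. Compound 3 `CS/C(=N\C(=O)c1cccs1)NC(=O)c1cccs1` keeps the core of compound 1 and differs only in that (a group of 2 heavy atoms (1 carbon, 1 sulfur; no ring) in place of a group of 2 heavy atoms (1 carbon, 1 selenium; no ring), on a carbon with a double bond to nitrogen). For the measured compounds named here, no measured pair shows this exchange, so its effect is unknown. The step from compound 1 to compound 3 in this assay is expected to be a modest rise, a 2.4-fold higher number from compound 1 to compound 3 (0.38 log units; beyond the scatter), slightly beyond the scatter. Compound 3 is therefore estimated at 30000 nM, between 10000 nM and 100000 nM.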

Compound 3, concentration lethal to 50% of the cells: > 100000 nM
Compound 3: a limit, no number; the forecaster's own chance of this, stated with the estimate: 15%; middle value at least 3.3-fold (0.52 log units) away from the limit.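

In this assay, methylsulfanyl in place of the selenium-bearing group, on a carbon with a double bond to nitrogen whose other neighbours are amide-type nitrogens, gives an at least 8.0-fold higher number from compound 1 to compound 3 (0.90 log units; beyond the scatter). With the rest of the structure unchanged, this ties the higher toxicity in this test of compound 1 to the selenium-bearing group. Compound 3 gives > 100000 nM, which is a limit of the assay and not a number, so the step has a lower bound only: the limit of > 100000 nM in this assay, at which 1 of the 3 values shown sits.

From the compounds shown here alone, whether a methoxy group or an amine on that carbon would behave like methylsulfanyl remains open. So does the effect of a longer chain on the selenium.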